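The source may hold more compounds than are shown below. What is called first, only, known or untested is meant among the compounds shown, and "the series" means these compounds.

Of the compounds shown here, three have been tested so far in a functional assay on HL-60 cells (Homo sapiens) for antiproliferative activity, read by sulforhodamine B assay, with a stated time of 72 h; on this read-out higher numbers stand for weaker inhibition and lower numbers for stronger inhibition. Compound 1 `CN(C)C(=S)N/N=C/c1ccc2cccnc2n1` gives 560 nM. Compound 2 `S=C(N/N=C/c1ccc2ccccc2n1)Nc1cccc(Br)c1` gives 53800 nM, the higher of the two true numbers and well beyond the scatter from compound 1. The value of compound 3 `NC(=S)N/N=C/c1cc2ccccc2s1` is a limit of the assay, > 100000 nM. Compound 4 `Fc1ccc(NC(=S)N/N=C/c2ccc3ccccc3n2)cc1` keeps the core of compound 2 and has 4-fluorophenyl in place of 3-bromophenyl on an amide-type nitrogen. Going by the values given here, no pair of measured compounds shows such a change in this assay, so no shift beyond the scatter is expected in either direction. The expected step is a 1.8-fold lower number from compound 2 to compound 4 (0.25 log units; within the scatter). For compound 4 the estimated value is 30000 nM, with an expected range from 5000 nM to 100000 nM.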

Compound 4, half-maximal inhibitory concentration: 17000 nM
For compound 4 the middle estimate is 1.8-fold (0.25 log units) above the measured one, and the stated range covers the measured number.
By their numbers in this assay, from the lowest: compound 1; then compound 4; then compound 2. At a limit, above all of these: compound 3.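

In this assay, the aryl group on the amide-type nitrogen whose other neighbour is the thiocarbonyl carbon proves able to shift the number: 4-fluorophenyl in place of 3-bromophenyl gives a modest gain (a 3.2-fold lower number from compound 2 to compound 4 (0.50 log units; beyond the scatter)). This single pair shows that the position responds to this exchange, but it sets no trend. Nothing measured here accounts for the step.

Because the halogen and its ring position change together, their contributions remain unseparated. From the compounds shown here alone, how 4-bromophenyl, unsubstituted phenyl or a morpholine ring would behave at this nitrogen also remains open.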